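This account rests on a few compounds, and the source may have more. Where it says the series, first, only, none or still open, it means among the compounds named here.

Measured so far:
compound 1 `CCC(=O)CCc1ccc2cc(OC)ccc2c1` gives 7%
compound 2 `CC(=O)CCc1ccc2cc(OC(C)=O)ccc2c1` gives 2%

Both numbers come from a functional assay on the whole organism (strain Wistar) for inhibition, with Rattus norvegicus as the target, with a stated time of 5 days, at a dose of 50 mg/kg by the oral route; a lower number here means less inhibition, a higher number more inhibition at the dose given (going by the name of the read-out). Compound 2 stands at the lower of the two; compound 1 lies a few points higher, a gap within the scatter, so no order between them is claimed. Compound 3 `CC(=O)CCc1ccc2ccccc2c1` is not yet measured. Against compound 2 the change is hydrogen in place of acetoxy on an aromatic carbon. Among the compounds with values here, no measured pair isolates this change, so its size is unknown. With both measured compounds low and close together, the expected step is a number 3 percentage points higher from compound 2 to compound 3 (within the scatter), within the scatter and in no clear direction. Compound 3 is estimated at 5%, with a range from 0% to 15%.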

Compound 3, a percentage reported as inhibition, in the whole organism at one dose (the size of the read-out at that dose, not a potency): 20%
Compound 3: the middle estimate sits 15 percentage points below what was measured, outside the stated range (above it).
By their numbers in this assay, from the lowest: compounds 2 and 1 (each within the scatter of the next); then compound 3.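

In this assay, within the data shown here, hydrogen in place of acetoxy on an aromatic carbon gives a number 18 percentage points higher from compound 2 to compound 3 (beyond the scatter), the first single-place change. The read-out at this dose therefore depends on what occupies this position, which compounds 1 and 2 could not show, as they differ in more than one place. No evidence bearing on the reason for this step is available.

From the compounds shown here alone, whether other groups at this carbon would match hydrogen or acetoxy remains open. A hydroxyl or an amine there would help to settle this.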